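This account rests on a few compounds, and the source may have more. Where it says the series, first, only, none or still open, it means among the compounds named here.

Measured in an in vitro ADME assay on microsomes from liver (Homo sapiens) for pharmacokinetics, read by LC-MS, with a stated time of 10 min, tested at 1 uM; a lower number here means slower removal, a higher number faster removal of the compound:
compound 1 `CN1C[C@H](C(=O)Nc2ccc(F)c(Br)c2)[C@@H](c2ccc(/C=C/C(=O)Nc3ccccc3N)cc2)C1`: 15 mL/min/kg
compound 2 `CN1C[C@H](C(=O)Nc2ccc(Cl)cc2F)[C@@H](c2ccc(/C=C/C(=O)Nc3ccccc3N)cc2)C1`: 11 mL/min/kg
compound 3 `CN1C[C@H](C(=O)Nc2ccccn2)[C@@H](c2ccc(/C=C/C(=O)Nc3ccccc3N)cc2)C1`: 8 mL/min/kg

These three compounds share a core and differ only in the group on the amide-type nitrogen. Compound 3, at 8 mL/min/kg, cannot be separated from the other two: the steps are a 1.9-fold lower number from compound 1 to compound 3 (0.27 log units; within the scatter) and a 1.4-fold lower number from compound 2 to compound 3 (0.14 log units; within the scatter).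

Compound 4 `CN1C[C@H](C(=O)N2CCCCC2)[C@@H](c2ccc(/C=C/C(=O)Nc3ccccc3N)cc2)C1` keeps the shared core but changes the same region. On a carbonyl carbon whose other neighbours are a saturated ring carbon, piperidin-1-yl stands in place of (pyridin-2-yl)amino: piperidin-1-yl in place of (pyridin-2-yl)amino on a carbonyl carbon. A six-membered aromatic ring thus gives way to a six-membered non-aromatic ring.

The closest evidence comes from the swaps already made in this region. The largest is a 1.9-fold lower number from compound 1 to compound 3 (0.27 log units; within the scatter), and the other two are a 1.4-fold lower number from compound 1 to compound 2 (0.13 log units; within the scatter) and a 1.4-fold lower number from compound 2 to compound 3 (0.14 log units; within the scatter). All of them stay within the scatter. Going by the values given here, none of the measured compounds has a non-aromatic ring here, however, so this expectation extends beyond what has been tested. A step beyond the scatter is therefore not expected in this assay, and no firm direction can be given. The estimated step is a 1.3-fold higher number from compound 3 to compound 4 (0.10 log units; within the scatter). For compound 4 the expected value is 10 mL/min/kg, with an estimated range of 5 mL/min/kg to 20 mL/min/kg.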

Compound 4, clearance: 9 mL/min/kg
Compound 4: middle estimate off by 1.1-fold (0.05 log units), on the high side, and the stated range covers the measured number.
By their numbers in this assay, from the lowest: compounds 3, 4, 2 and 1 (each within the scatter of the next).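

In this assay, the change from an aromatic ring on an amide-type nitrogen to piperidin-1-yl on a carbonyl carbon, which also removes the amide hydrogen, stays within the scatter in all three comparisons (a 1.1-fold higher number from compound 3 to compound 4 (0.05 log units; within the scatter)) and (a 1.2-fold lower number from compound 2 to compound 4 (0.09 log units; within the scatter)) and (a 1.7-fold lower number from compound 1 to compound 4 (0.22 log units; within the scatter)). The earlier compounds shown here only showed swaps from one aromatic ring to another, whereas this position now also holds a non-aromatic ring, and the read-out does not separate compound 4 from compounds 1, 2 and 3. No measurement available here accounts for this absence of a clear difference.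

On these data alone, what remains open is whether this holds for other groups on the same carbonyl carbon, such as morpholin-4-yl, which brings a ring oxygen, or diethylamino, which has open chains in place of a ring. A group carrying a carboxylic acid or a further amine could also be placed here, and the compounds shown cannot say whether either would produce a step beyond the scatter.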